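Extending the Ethoxy Chain: Cytotoxicity Held at the Limit

The source may report more compounds than this note shows. Statements on the series, on what has been measured and on what is new or still open speak of the compounds shown alone.

Compound 1, `Nc1nc(NCc2ccccc2)c2ncn(/C=C3/CC3(CO)CO)c2n1`, gives in an ADME assay on MOLT-3 cells (Homo sapiens) for cytotoxicity, with a stated time of 7 days (a lower number here means that less compound is tolerated, a higher number that more compound is tolerated), a limit of > 20000 nM.
Compound 2, `Nc1nc(NC2CCCC2)c2ncn(/C=C3/CC3(CO)CO)c2n1`, gives in this assay a limit of > 20000 nM.
Compound 3, `CCOc1nc(N)nc2c1ncn2/C=C1/CC1(CO)CO`, gives in this assay a limit of > 20000 nM.

None of these three values is a number; each is a limit of this assay, and (the limit of > 20000 nM in this assay, at which 3 of the 3 values shown sit). Compound 3 therefore cannot be placed above or below its two companions: the three simply share the same limit. The steps between them are correspondingly silent: a step that the two limits leave unreadable from compound 1 to compound 2, a step that the two limits leave unreadable from compound 1 to compound 3 and a step that the two limits leave unreadable from compound 2 to compound 3.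

Compound 4, `CCCCOc1nc(N)nc2c1ncn2/C=C1/CC1(CO)CO`, is still to be measured in this assay. It differs from compound 3 by ethyl in place of hydrogen on a saturated chain carbon, two bonds along the chain from an oxygen on an aromatic ring. Among the compounds with values here, no measured step touches this position, so there is no read on what lengthening the chain should do. Within the data shown here, the only evidence is that every compound so far sits at the limit, which makes a limit the most likely outcome again. Compound 4 is accordingly expected to give about 30000 nM, between 12000 nM and 100000 nM, and the step from compound 3 is estimated to be a step that the limit leaves unreadable from compound 3 to compound 4.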

Compound 4, half-maximal cytotoxic concentration: > 20000 nM
Compound 4: only a limit was reported (the forecaster's own chance of this, stated with the estimate: 80%); the middle value lies beyond the limit too.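

Compound 4 also gives only a limit, so no step among compound 1, compound 2, compound 3 and compound 4 can be read, and all four share the same limit: the limit of > 20000 nM in this assay, at which 4 of the 4 values shown sit.

On these data alone, what stays open is where each compound's true value lies, and so whether exchanging these groups changes anything in this assay.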